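Compound 2 to compound 3: a longer ester chain

This account rests on a few compounds, and the source may have more. Where it says the series, first, only, none or still open, it means among the compounds named here.

Within the data shown here, in an ADME assay on Vero cells (Chlorocebus sabaeus) for cytotoxicity, read by MTT assay (a higher number here means a weaker inhibitor, a lower number a stronger inhibitor), compound 2 (`CCCCCCCCCCCCCC(=O)OCC(C)(C)CC1=C(O)C(=O)c2ccccc2C1=O`) gives 58400 nM, the only exact number so far. Compound 1 (`CCCCCCCC(=O)OCC(C)(C)CC1=C(O)C(=O)c2ccccc2C1=O`) gives only a limit, > 258000 nM. Compound 3 (`CCCCCCCCCCCCCCCCCC(=O)OCC(C)(C)CC1=C(O)C(=O)c2ccccc2C1=O`) differs from compound 2 by butyl in place of hydrogen on a saturated chain carbon, ten or more bonds along the chain from a carbonyl carbon. Among the measured compounds shown here, one measured step bears on this change: an at least 4.4-fold lower number from compound 1 to compound 2 (0.64 log units; beyond the scatter), which put hexyl in place of hydrogen on the same chain and starts from that limit. For the measured compounds named here, with only this step as a guide, butyl is expected to move the number the same way, but less far. The expected size is a 1.7-fold lower number from compound 2 to compound 3 (0.22 log units; within the scatter). Compound 3 is estimated at 35000 nM, with an expected range of 12000 nM to 110000 nM.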

Compound 3, half-maximal inhibitory concentration: 15500 nM
For compound 3 the middle estimate is 2.3-fold (0.35 log units) above the measured one; low and high end bracket the measured number.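

In this assay, the step between two exact numbers shows the fall continuing along the ester chain: butyl in place of hydrogen gives a 3.8-fold lower number from compound 2 to compound 3 (0.58 log units; beyond the scatter). Over the whole chain, decyl in place of hydrogen gives an at least 16-fold lower number from compound 1 to compound 3 (1.22 log units; beyond the scatter), and across these three compounds none goes against the trend. That longer step starts from compound 1, which stands only at a limit: the limit of > 258000 nM in this assay, at which 1 of the 3 values shown sits.

From the compounds shown here alone, whether a still longer chain lowers the number further remains open. So does whether a chain ending in an amine or a carboxylic acid would follow the same course.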